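Nitro for Methoxy on Two Related Ketone Cores

A few compounds are considered here, and "the series" means these few. Any claim that something is new, unique, unknown or untested is made for them only; others in the source may bear on it.

Measured compounds:
Compound 1, `COc1ccc(Cn2cc(CO[C@H]3CC(=O)[C@@H]4OC[C@H]3O4)nn2)cc1`: 34800 nM
Compound 2, `O=C1C[C@H](OCc2cn(Cc3ccc([N+](=O)[O-])cc3)nn2)[C@H]2CO[C@@H]1O2`: 25400 nM
Compound 3, `COc1ccc(-c2cc(CO[C@H]3CC(=O)[C@@H]4OC[C@H]3O4)on2)cc1`: 21900 nM

Of the compounds shown here, three have been measured in a functional assay on MDA-MB-231 cells (Homo sapiens) for cytotoxicity, read by MTT assay, with a stated time of 48 h; a lower number here means a stronger inhibitor, a higher number a weaker inhibitor. Compound 1 and compound 2 share one core; compound 3 has a different core, and the difference between the two cores is not broken down here. The change from compound 1 to compound 2 is nitro in place of methoxy on an aromatic carbon, and it made a step of a 1.4-fold lower number from compound 1 to compound 2 (0.14 log units; within the scatter).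

Compound 4, `O=C1C[C@H](OCc2cc(-c3ccc([N+](=O)[O-])cc3)no2)[C@H]2CO[C@@H]1O2`, is not yet measured. Among the compounds with values here, it differs from compound 3 by nitro in place of methoxy on an aromatic carbon, the same change, at the same place, as the one from compound 1 to compound 2. Because that earlier step was a 1.4-fold lower number from compound 1 to compound 2 (0.14 log units; within the scatter), the expectation for compound 3 to compound 4 is a step of the same size, estimated as a 1.4-fold lower number from compound 3 to compound 4 (0.15 log units; within the scatter). Within the data shown here, only one instance of the change is measured, so this rests on a single pair of compounds. Compound 4 is estimated at 15600 nM, with a range from 7800 nM to 31000 nM expected in this assay.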

Compound 4, half-maximal inhibitory concentration: 16500 nM
Beside the measured number, compound 4's estimate is 1.1-fold (0.02 log units) below it; measured number inside the range.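

In this assay, nitro in place of methoxy on an aromatic carbon gave a 1.3-fold lower number from compound 3 to compound 4 (0.12 log units; within the scatter). Set beside the same change on the other core, the two steps do not differ: the same change on two cores in this assay, a 1.4-fold lower number (0.14 log units; within the scatter) from compound 1 to compound 2 and a 1.3-fold lower number (0.12 log units; within the scatter) from compound 3 to compound 4, 1.0-fold (0.01 log units) apart, within the scatter of two such steps. This shows that, for these two pairs of compounds, the change carried over from one core to the other with a step of matching size, but both steps lie within the scatter, so it does not show that nitro in place of methoxy truly alters the number on either core, nor that the agreement would hold on a third core.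

The compounds shown leave open whether a group at that aromatic carbon could give a step beyond the scatter, for instance an amine, a carboxylic acid or a chlorine atom. They also leave open whether such a step would carry from one core to the other as closely as this one did.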